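Removing the methoxy from compound 2

The compounds below may be only part of what the source reports. "The series", "measured", "known", "first", "only" and "open" are said of these compounds alone.

Measured so far in an ADME assay on microsomes from liver (Homo sapiens) for metabolic stability, read by LC-MS, using NADPH, with a stated time of 10 min, tested at 10 uM; a lower number here means that the compound disappears faster, a higher number that the compound lasts longer:
Compound 1 `Nc1ncnc2c1c(Oc1cc(C(F)(F)F)ccn1)nn2[C@H]1CC[C@H](CO)CC1`: > 2.41 h (a limit, not a number)
Compound 2 `CO[C@H]1CC[C@@H](n2nc(Oc3cc(C(F)(F)F)ccn3)c3c(N)ncnc32)CC1`: 0.317 h

Among the compounds with values here, compound 2 holds the only true number in this short series, with a half-life of 0.317 h. Compound 1 is reported only as a limit, > 2.41 h. Within the data shown here, the single measured step is an at least 7.6-fold lower number from compound 1 to compound 2 (0.88 log units; beyond the scatter), where 4-methoxycyclohexyl stands in place of 4-(hydroxymethyl)cyclohexyl on an aromatic nitrogen.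

Compound 3 `Nc1ncnc2c1c(Oc1cc(C(F)(F)F)ccn1)nn2C1CCCCC1` has not yet been measured. It differs from compound 2 as follows: hydrogen in place of methoxy on a saturated ring carbon. This is hydrogen in place of methoxy on a saturated ring carbon, or 4-methoxycyclohexyl to cyclohexyl.

The measured step bears on this change only loosely. It concerns the same saturated ring, but it swaps one group for another and does not remove one, and its size rests on a limit. Compound 3 also lacks the hydroxymethyl of compound 1, so the nearer reference is compound 2 at 0.317 h. In this assay, no change beyond the scatter is therefore expected, and the expected step is a 1.3-fold lower number from compound 2 to compound 3 (0.10 log units; within the scatter). For compound 3 the estimated half-life is 0.25 h, within an expected range of 0.1 h to 0.7 h.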

Compound 3, half-life: 0.55 h
Estimate against measurement, compound 3: 2.2-fold (0.34 log units) below; the measured number falls inside the stated range.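

In this assay, hydrogen in place of methoxy on a saturated ring carbon gives a 1.7-fold higher number from compound 2 to compound 3 (0.24 log units; within the scatter), so the cyclohexyl and 4-methoxycyclohexyl compounds cannot be told apart here, and the methoxy shows no measurable effect on the half-life at this position. With the unsubstituted cyclohexyl now available as a reference, the gap first seen between the two substituted rings sits with the hydroxymethyl, since hydrogen in its place on the same ring carbon gives an at least 4.3-fold lower number from compound 1 to compound 3 (0.64 log units; beyond the scatter), a step that stays beyond the scatter. This step is only a lower bound on the size of the gap, as compound 1 is reported as a limit and not as a number: the limit of > 2.41 h in this assay, at which 1 of the 3 values shown sits.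

The compounds shown leave open how far the hydroxymethyl compound truly lies from the other two, and whether that gap needs the hydroxyl oxygen or only a group of that length on the ring carbon. A hydroxyl set directly on that ring carbon, an amine or a carboxylic acid there, or a longer hydroxyalkyl chain would each address a part of this question.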